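Three Limits and an Ethyl Group Added to the Core

This account rests on a few compounds, and the source may have more. Where it says the series, first, only, none or still open, it means among the compounds named here.

Compound 2 `O=c1c(-c2nn[nH]n2)c[nH]c2ccccc12` is the member of the set with hydrogen at the position that is varied. In a functional assay on the whole organism (strain Sprague-Dawley) for inhibition, with Rattus norvegicus as the target (on this read-out higher numbers stand for an effect only at larger amounts of compound and lower numbers for an effect already at smaller amounts), compound 2 gives > 20 mg/kg, and this is a limit of the assay rather than a number (the limit of > 20 mg/kg in this assay, at which 1 of the 3 values shown sits). Compound 1 `O=c1c(-c2nn[nH]n2)c[nH]c2c(Br)cccc12` carries a bromo group on an aromatic carbon of the same core. In this assay compound 1 gives > 10 mg/kg, again only a limit (the limit of > 10 mg/kg in this assay, at which 1 of the 3 values shown sits). Compound 3 `O=c1c(-c2nn[nH]n2)c[nH]c2c(C(F)(F)F)cccc12` carries a trifluoromethyl group at that carbon. In this assay compound 3 gives > 25 mg/kg, which is also a limit (the limit of > 25 mg/kg in this assay, at which 1 of the 3 values shown sits). Compound 2 therefore stands among three values of which none is an actual number, and the steps a step that the two limits leave unreadable from compound 1 to compound 2 and a step that the two limits leave unreadable from compound 2 to compound 3 are both unreadable in size and direction.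

Compound 4 `CCc1ccc2c(=O)c(-c3nn[nH]n3)c[nH]c2c1` differs from compound 2 by ethyl in place of hydrogen on an aromatic carbon. Going by the values given here, the steps that bear on this change are the two single-group changes on an aromatic carbon just named, and neither gives a readable size, so no step beyond the scatter can be expected in either direction. Compound 4 is thus expected to give about 30 mg/kg, within 10 mg/kg to 100 mg/kg. The expected step that the limit leaves unreadable from compound 2 to compound 4 is accordingly small, and a further limit is the likeliest outcome.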

Compound 4, minimum effective dose: > 10 mg/kg
Compound 4: only a limit was reported; the forecaster's own chance of this, stated with the estimate: 70%; the middle value does not contradict the limit.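

In this assay compound 4 gives > 10 mg/kg, which is a limit of the assay and not a number. Going by these compounds alone, compound 2 also has only a limit, so no step between compound 2 and compound 4 can be read. Compounds 1 to 4 leave open whether bromo, hydrogen, trifluoromethyl or ethyl on the shared core changes the dose needed for an effect.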